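Ethyl ester in place of Weinreb amide on a purine series

The source may report more compounds than this note shows. Statements on the series, on what has been measured and on what is new or still open speak of the compounds shown alone.

Compound 1 `CCOC(=O)C[C@H]1[C@@H](O[Si](C)(C)C(C)(C)C)[C@H](n2cnc3c(NC(=O)Nc4ccccc4)ncnc32)O[C@@H]1COC(=O)NC`: 11.8 nM
Compound 2 `CNC(=O)NC[C@H]1O[C@@H](n2cnc3c(NC(=O)Nc4ccccc4)ncnc32)[C@H](O[Si](C)(C)C(C)(C)C)[C@@H]1CC(=O)N(C)OC`: 41.9 nM

In a functional assay on NCI-H226 cells (Homo sapiens) for antiproliferative activity (on this read-out lower numbers stand for stronger inhibition of growth and higher numbers for weaker inhibition of growth), compound 2 stands at the higher of the two numbers, and compound 1 gives the lower one, a gap beyond the usual scatter. Compound 3 `CCOC(=O)C[C@H]1[C@@H](O[Si](C)(C)C(C)(C)C)[C@H](n2cnc3c(NC(=O)Nc4ccccc4)ncnc32)O[C@@H]1CNC(=O)NC` has not yet been measured. It differs from compound 2 at one place: ethoxy in place of methoxy(methyl)amino on a carbonyl carbon. Compound 3 now carries the ethoxycarbonyl group that compound 1 also bears, so compound 3 is expected to give a lower number than compound 2, with a step of a 2.1-fold lower number from compound 2 to compound 3 (0.32 log units; beyond the scatter) in this assay. Compound 3 is estimated at 20 nM, within a range from 8 nM to 50 nM.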

Compound 3, concentration for 50% growth inhibition: > 100 nM
Compound 3: a limit, no number (the forecaster's own chance of this, stated with the estimate: 2%); at least 5.0-fold (0.69 log units) between middle value and limit.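

In this assay compound 3 reaches only a limit, > 100 nM, and not a number. Ethoxy in place of methoxy(methyl)amino on this carbonyl carbon gives an at least 2.3-fold higher number from compound 2 to compound 3 (0.37 log units; beyond the scatter), and (methylcarbamoyl)amino in place of (methylcarbamoyl)oxy on the saturated chain carbon gives an at least 8.4-fold higher number from compound 1 to compound 3 (0.92 log units; beyond the scatter), so the ethoxycarbonyl group alone does not secure a low number. Both steps are minimum sizes, set by one value: the limit of > 100 nM in this assay, at which 1 of the 3 values shown sits.

On these data alone, the true size of both steps stays open. So does how a carboxylic acid or a dimethylamino group would read on this carbonyl carbon.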